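A few compounds are considered here, and "the series" means these few. Any claim that something is new, unique, unknown or untested is made for them only; others in the source may bear on it.

Working notes on the series, read in an ADME assay on BJ cells (Homo sapiens) for cytotoxicity, with a stated time of 72 h; a higher number here means that more compound is needed for the effect, a lower number that less compound is needed. Compound 1 (`C=C[C@@](C)(/C=C/c1ccc(O)cc1)CCC1OC1(C)C`) gives > 36600 nM, which is a limit and not a number. Compound 2 (`C=C[C@@](C)(/C=C/c1ccc(O)cc1)CC/C=C/C(=O)OCC`) gives > 36600 nM, also a limit and not a number, so its standing is known only as a limit. The whole picture so far is the limit of > 36600 nM in this assay, at which 2 of the 2 values shown sit.

Compound 3 (`C=C[C@@](C)(/C=C/c1ccc(O)cc1)CC/C=C(C)/C=N/N`) changes compound 2 at one place: a group of 6 heavy atoms (4 carbon, 2 nitrogen; no ring) in place of a group of 7 heavy atoms (5 carbon, 2 oxygen; no ring), on a saturated chain carbon, three bonds along the chain from two double-bonded chain carbons. The entering group has no common name.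

Among the compounds with values here, the only measured step at this place on the chain is a step that the two limits leave unreadable from compound 1 to compound 2. It therefore gives no size to carry over and no direction. With nothing readable to go on, no step beyond the scatter is expected in this assay, and a further limit is the likeliest report. The estimated step, which is a working figure only, is an at least 1.0-fold lower number from compound 2 to compound 3 (0.01 log units; that floor lies within the scatter). For compound 3 the expected value is 35000 nM, with an estimated range from 14000 nM to 70000 nM.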

Compound 3, half-maximal effective concentration: > 36600 nM
Compound 3 ended at the assay's limit; the forecaster's own chance of this, stated with the estimate: 65%; at least 1.0-fold (0.01 log units) between middle value and limit.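

In this assay, within the data shown here, compound 1, compound 2 and compound 3 all end at a limit and not a number, so no step among them can be read. The compounds shown leave open whether any group at this place on the chain gives a readable value, and the whole picture remains: the limit of > 36600 nM in this assay, at which 3 of the 3 values shown sit.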